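The source may hold more compounds than are shown below. What is called first, only, known or untested is meant among the compounds shown, and "the series" means these compounds.

Compound 2 `CCN(CC)C(=O)CN(c1ccc(C)cc1)S(=O)(=O)c1ccc(OC)cc1` is the point of departure for this note. In a functional assay on CHO cells for inhibition of Orexin/Hypocretin receptor type 1 (Homo sapiens), read by FLIPR and calcium flux (on this read-out higher numbers stand for weaker inhibition and lower numbers for stronger inhibition), compound 2 gives only a limit, > 10000 nM, and no number. Compound 1 `CCN(CC)C(=O)CN(c1ccc(C)cc1)S(=O)(=O)c1ccc(OC(F)(F)F)cc1` carries a trifluoromethyl in place of the methyl on the oxygen on the aromatic ring. In this assay compound 1 likewise gives a limit, > 10000 nM. The step that the two limits leave unreadable from compound 1 to compound 2 therefore cannot be sized; both values sit at the limit of > 10000 nM in this assay, at which 2 of the 2 values shown sit. Compound 3 `CCN(CC)C(=O)CN(c1ccc(C)cc1)S(=O)(=O)c1ccc(C(C)(C)C)cc1` is the next member; the change is tert-butyl in place of methoxy on an aromatic carbon. Going by the values given here, no measured step bears on this change: the only recorded step is unreadable. The working expectation is that compound 3 again stops at the limit, so the estimated step that the limit leaves unreadable from compound 2 to compound 3 is of no readable size. For compound 3 the estimate in this assay is 20000 nM, within 3000 nM to 100000 nM, and it is expected that most likely only a limit is reported again.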

Compound 3, half-maximal inhibitory concentration: > 10000 nM
Compound 3: no number, only a limit; the forecaster's own chance of this, stated with the estimate: 80%; the middle value is on the limit's open side.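

No step can be read among compound 1, compound 2 and compound 3 in this assay, and the new steps to compound 3 remain unsized: the limit of > 10000 nM in this assay, at which 3 of the 3 values shown sit.

The compounds shown leave open whether any group at this place on the shared core gives a measurable half-maximal inhibitory concentration.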